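The compounds below may be only part of what the source reports. "The series", "measured", "known", "first", "only" and "open" are said of these compounds alone.

Measured compounds:
compound 1 `COc1ccc(/C=C2\NC(=O)N(CCCN3CCN(c4cccc(Cl)c4Cl)CC3)C2=O)cc1OC` — 22 nM
compound 2 `COc1ccc(/C=C2\NC(=O)N(CCCN3CCN(c4ncccn4)CC3)C2=O)cc1OC` — 74 nM
compound 3 `COc1ccc(/C=C2\NC(=O)N(CCCCN3CCN(c4cccc(Cl)c4Cl)CC3)C2=O)cc1OC` — 0.8 nM

In an assay on CHO cells for displacement of a labelled ligand from 5-hydroxytryptamine receptor 7 (Homo sapiens), read by scintillation counting, with a stated time of 60 min (on this read-out lower numbers stand for stronger inhibition and higher numbers for weaker inhibition), compound 1 stands second highest of the three numbers. Its nearest neighbour is compound 2, reached by a 3.4-fold higher number from compound 1 to compound 2 (0.53 log units; beyond the scatter). Among the measured compounds shown here, the furthest is compound 3, whose value 0.8 nM lies well below that of compound 1 22 nM; compound 3 differs from compound 1 in the chain between the imide nitrogen and the piperazine, and no single-place step for that pair is set out here.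

The step to compound 4 `COc1ccc(/C=C2\NC(=O)N(CCCN3CCN(c4cccc(Cl)c4Cl)CC3)C2=O)cc1OC1CCCC1` is cyclopentyl in place of methyl on an oxygen on an aromatic ring. For the measured compounds named here, neither measured step touches this position: the one step in this assay changes the aryl on the piperazine nitrogen, and the change from compound 1 to compound 3 concerns the chain. Going by the values given here, there is therefore no measured step that bears on the methoxy-to-cyclopentyloxy change, and the expectation rests on compound 1 alone. For compound 4 the expected value is 30 nM, in the range 6 nM to 150 nM. The expected step is a 1.4-fold higher number from compound 1 to compound 4 (0.13 log units; within the scatter), not beyond the scatter in either direction, with wide uncertainty.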

Compound 4, inhibition constant: 380 nM
For compound 4 the middle estimate is 13-fold (1.10 log units) below the measured one; measured number outside the range, above it.
By their numbers in this assay, from the lowest: compound 3; then compound 1; then compound 2; then compound 4.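

In this assay, among the compounds shown here, the oxygen on the aromatic ring proves to be a sensitive place: methoxy to cyclopentyloxy gives a 17-fold higher number from compound 1 to compound 4 (1.24 log units; beyond the scatter), the first measured change at this position. The change swaps a methyl for a cyclopentyl, adding carbon atoms and a five-membered ring of carbon only, with no hydrogen-bond donor or acceptor entering or leaving, so the step is tied to a change in the carbon group alone. No measured information here accounts for the size of this step.

Going by these compounds, with only methyl and cyclopentyl at this oxygen, it remains open how the number moves through intermediate groups such as ethyl, isopropyl or cyclopropylmethyl, or with a free hydroxyl in place of the ether. Also open, on these data alone, is whether cyclopentyloxy has a step of similar size on the chain of compound 3 or with the pyrimidin-2-yl of compound 2.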